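This account rests on a few compounds, and the source may have more. Where it says the series, first, only, none or still open, it means among the compounds named here.

Measured so far in an ADME assay on BJ cells (Homo sapiens), read by MTT assay, with a stated time of 72 h; on this read-out lower numbers stand for stronger inhibition and higher numbers for weaker inhibition:
compound 1 `COc1ncnc2c1c(-c1ccoc1)cn2[C@@H]1O[C@H](CO)[C@@H](O)[C@H]1O`: 28800 nM
compound 2 `Cc1ncnc2c1c(-c1ccoc1)cn2[C@@H]1O[C@H](CO)[C@@H](O)[C@H]1O`: 89200 nM
compound 3 `COc1ncnc2c1c(-c1cccs1)cn2[C@@H]1O[C@H](CO)[C@@H](O)[C@H]1O`: 62800 nM

Compound 1 and compound 2 differ by methyl in place of methoxy on an aromatic carbon; that change gave a 3.1-fold higher number from compound 1 to compound 2 (0.49 log units; beyond the scatter). Compound 1 and compound 3 differ by thiophen-2-yl in place of furan-3-yl on an aromatic carbon, with a step of a 2.2-fold higher number from compound 1 to compound 3 (0.34 log units; beyond the scatter). Compound 2 and compound 3 give numbers within the usual scatter of each other, so no order is read between them.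

Compound 4 `Cc1ncnc2c1c(-c1cccs1)cn2[C@@H]1O[C@H](CO)[C@@H](O)[C@H]1O` is not yet measured in this assay. It differs from compound 3 by methyl in place of methoxy on an aromatic carbon, the same change as from compound 1 to compound 2, made at a place described in the same words. The two cores differ by the thiophen-2-yl in place of furan-3-yl already noted. The expectation for compound 4 is a step of a 2.7-fold higher number from compound 3 to compound 4 (0.43 log units; beyond the scatter), set beside the measured 3.1-fold higher number from compound 1 to compound 2 (0.49 log units; beyond the scatter) and resting on that single earlier example of the change; a single pair is a thin base, so the range is kept wide. Compound 4 is thus estimated at 170000 nM, between 80000 nM and 400000 nM.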

Compound 4, half-maximal inhibitory concentration: > 100000 nM
Compound 4: a limit, no number (the forecaster's own chance of this, stated with the estimate: 20%); the middle value lies beyond the limit too.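

In this assay compound 4 gives > 100000 nM, which is a limit of the assay and not a number. Methyl in place of methoxy on the thiophen-2-yl core reads as an at least 1.5-fold higher number from compound 3 to compound 4 (0.20 log units; that floor lies within the scatter), which fits a carry-over from the furan-3-yl core but does not establish one, and the size of the step on this core stays unknown: the same change on two cores in this assay, a 3.1-fold higher number (0.49 log units; beyond the scatter) from compound 1 to compound 2 and an at least 1.5-fold higher number (0.20 log units; that floor lies within the scatter) from compound 3 to compound 4; the limit leaves it open whether they differ Thiophen-2-yl in place of furan-3-yl on the methyl core reads as an at least 1.1-fold higher number from compound 2 to compound 4 (0.04 log units; that floor lies within the scatter), which likewise fits the earlier step without confirming it: the same change on two cores in this assay, a 2.2-fold higher number (0.34 log units; beyond the scatter) from compound 1 to compound 3 and an at least 1.1-fold higher number (0.04 log units; that floor lies within the scatter) from compound 2 to compound 4; the limit leaves it open whether they differ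

The compounds shown leave open how far the true figure for compound 4 lies past the limit, and so whether the two changes simply add up when combined on one core. They also leave open what an amine or a longer chain such as ethoxy would give in place of methoxy or methyl on either core.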